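Swapping fluoro for methyl on the triazole-linked phenyl ring

The compounds below may be only part of what the source reports. "The series", "measured", "known", "first", "only" and "open" are said of these compounds alone.

Measured compounds:
- compound 1, `COc1cc2c(Oc3ccc(NC(=O)c4cn(-c5ccccc5C)nn4)cc3F)ccnc2cc1OCCCN1CCCCC1`: 3230 nM
- compound 2, `COc1cc2c(Oc3ccc(NC(=O)c4cn(-c5ccccc5)nn4)cc3F)ccnc2cc1OCCCN1CCN(C)CC1`: 160 nM
- compound 3, `COc1cc2c(Oc3ccc(NC(=O)c4cn(-c5ccccc5F)nn4)cc3F)ccnc2cc1OCCCN1CCN(C)CC1`: 250 nM

All three share one core and are judged in a functional assay on A549 cells (Homo sapiens) for cytotoxicity, read by MTT assay, with a stated time of 72 h; a lower number here means a stronger inhibitor, a higher number a weaker inhibitor. Among the measured compounds shown here, compound 3 stands second highest of the three numbers; its nearest neighbour is compound 2, and the only step with a single change, a 1.6-fold higher number from compound 2 to compound 3 (0.19 log units; within the scatter), is within the scatter, so the two cannot be ordered. Compound 1, which carries a methyl on the phenyl ring but a different basic tail, sits far higher than both.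

Compound 4, `COc1cc2c(Oc3ccc(NC(=O)c4cn(-c5ccccc5C)nn4)cc3F)ccnc2cc1OCCCN1CCN(C)CC1`, is compound 3 with methyl in place of fluoro on an aromatic carbon. For the measured compounds named here, no measured pair isolates this exact exchange with the tail held constant. Going by the values given here, compound 1 is the only measured compound bearing the methylphenyl group, and its number in this assay is much higher than those of compound 2 and compound 3, but it differs from compound 4 in the tail as well, so it is only a weak pointer. The step of a 2.4-fold higher number from compound 3 to compound 4 (0.38 log units; beyond the scatter) is therefore expected to be modest, toward a higher number, with wide uncertainty. Compound 4 is estimated at 600 nM, within a range from 150 nM to 2500 nM.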

Compound 4, half-maximal inhibitory concentration: 3100 nM
Compound 4: the middle estimate sits 5.2-fold (0.71 log units) below what was measured, and the stated range ends below it.
By their numbers in this assay, from the lowest: compounds 2 and 3 (each within the scatter of the next); then compounds 4 and 1 (each within the scatter of the next).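

In this assay, among the compounds shown here, this position turns out to be far less tolerant than the earlier compounds suggested: a 1.6-fold higher number from compound 2 to compound 3 (0.19 log units; within the scatter) lies within the scatter, yet a 12-fold higher number from compound 3 to compound 4 (1.09 log units; beyond the scatter) and a 19-fold higher number from compound 2 to compound 4 (1.29 log units; beyond the scatter) both lie beyond it. At this place on the ring, ortho to a large group, hydrogen and fluoro cannot be told apart, whereas the change from 2-fluorophenyl to 2-methylphenyl, which swaps just one heavy atom for another, gives a large step toward a weaker inhibitor. The tail also looks different now, since a 1.0-fold lower number from compound 1 to compound 4 (0.02 log units; within the scatter) lies within the scatter, so with 2-methylphenyl in place, 4-methylpiperazin-1-yl and piperidin-1-yl cannot be told apart, and the high number of compound 1 can no longer be pinned on its piperidin-1-yl tail. Nothing available explains why methyl and fluoro differ so much here.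

Going by these compounds, it remains open whether chloro or methoxy at this same place would fall with fluoro or with methyl. On these data alone, it is also open whether piperidin-1-yl would match 4-methylpiperazin-1-yl when the phenyl ring carries hydrogen or fluoro instead of methyl.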